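Expecting little change from a chlorophenyl swap

The compounds below may be only part of what the source reports. "The series", "measured", "known", "first", "only" and "open" are said of these compounds alone.

- compound 1 `C=C1CCC[C@]2(C)CCC(c3cn(-c4ccc(OC)cc4)nn3)=CC[C@@]12C` gives 58900 nM
- compound 2 `C=C1CCC[C@]2(C)CCC(c3cn(-c4cccc([N+](=O)[O-])c4)nn3)=CC[C@@]12C` gives 62500 nM
- compound 3 `C=C1CCC[C@]2(C)CCC(c3cn(-c4cccc(OC)c4)nn3)=CC[C@@]12C` gives 38900 nM

In a functional assay on DU-145 cells (Homo sapiens) for cytotoxicity, read by MTT assay, with a stated time of 48 h (a lower number here means a stronger inhibitor, a higher number a weaker inhibitor), compound 3 stands within the scatter of both other compounds. Not yet measured, compound 4 `C=C1CCC[C@]2(C)CCC(c3cn(-c4ccc(Cl)cc4)nn3)=CC[C@@]12C` has 4-chlorophenyl in place of 3-methoxyphenyl on an aromatic nitrogen. Three measured steps change this same group (a 1.1-fold higher number from compound 1 to compound 2 (0.03 log units; within the scatter)), (a 1.5-fold lower number from compound 1 to compound 3 (0.18 log units; within the scatter)) and (a 1.6-fold lower number from compound 2 to compound 3 (0.21 log units; within the scatter)), and all stay within the scatter. Going by the values given here, no compound with chlorine has been measured yet, so the evidence is indirect. In this assay no step beyond the scatter is therefore expected (a 1.2-fold higher number from compound 3 to compound 4 (0.09 log units; within the scatter)). Compound 4 is estimated at 48000 nM (expected range 24000 nM to 95000 nM).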

Compound 4, half-maximal inhibitory concentration: 26000 nM
For compound 4 the middle estimate is 1.8-fold (0.27 log units) above the measured one, within the range that was stated.
By their numbers in this assay, from the lowest: compounds 4, 3, 1 and 2 (each within the scatter of the next, the first and the last beyond it).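

In this assay, going by these compounds alone, 4-chlorophenyl on the aromatic nitrogen gives the only steps in this set that lie beyond the scatter (a 2.4-fold lower number from compound 2 to compound 4 (0.38 log units; beyond the scatter); a 2.3-fold lower number from compound 1 to compound 4 (0.36 log units; beyond the scatter)), so this position can shift the number modestly. The remaining step stays within the scatter (a 1.5-fold lower number from compound 3 to compound 4 (0.17 log units; within the scatter)), so compound 3 and compound 4 cannot be ranked. Nothing shown here explains the change. From the compounds shown here alone, what remains open is how far the number moves with a carboxylic acid or an amine on the phenyl ring, or with an alkyl chain replacing that ring.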